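This account rests on a few compounds, and the source may have more. Where it says the series, first, only, none or still open, it means among the compounds named here.

Compound 3 `N#CC1=C(N)Oc2c(N)cc3nc4ccccc4nc3c2C12C(=O)N(Cc1cnnn1-c1ccccc1Cl)c1ccccc12` gives 29800 nM in a functional assay on A549 cells (Homo sapiens) for antiproliferative activity, read by MTT assay, with a stated time of 48 h; a higher number here means a weaker inhibitor, a lower number a stronger inhibitor. Within the data shown here, compound 2 `N#CC1=C(N)Oc2c(c3nc4ccccc4nc3c3ccccc23)C12C(=O)N(Cc1cnnn1-c1ccc(Br)cc1)c1ccccc12` gives 44300 nM, a number that sits within the scatter of the one for compound 3. Compound 1 `Cc1ccccc1-n1nncc1CN1C(=O)C2(C(C#N)=C(N)Oc3c2c2nc4ccccc4nc2c2ccccc32)c2ccccc21` gives > 50000 nM, which is a limit of the assay rather than a number, (the limit of > 50000 nM in this assay, at which 1 of the 3 values shown sits). Compound 4 `Cc1ccc(C)c(-n2nncc2CN2C(=O)C3(C(C#N)=C(N)Oc4c(N)cc5nc6ccccc6nc5c43)c3ccccc32)c1` differs from compound 3 by 2,5-dimethylphenyl in place of 2-chlorophenyl on an aromatic nitrogen. Among the measured compounds shown here, the only measured step at the same place, an at least 1.1-fold lower number from compound 1 to compound 2 (0.05 log units; that floor lies within the scatter), starts from a limit and stays within the scatter, so this swap of aryl groups on the aromatic nitrogen gives no ground to expect a step beyond the scatter. The step expected from this change is a 1.0-fold higher number from compound 3 to compound 4 (0.00 log units; within the scatter). Compound 4 is therefore estimated at 30000 nM, between 12000 nM and 75000 nM.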

Compound 4, half-maximal inhibitory concentration: > 50000 nM
Compound 4: a limit, no number (the forecaster's own chance of this, stated with the estimate: 25%); middle value at least 1.6-fold (0.22 log units) from the limit.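

In this assay, 2,5-dimethylphenyl in place of 2-chlorophenyl on the aromatic nitrogen gives an at least 1.6-fold higher number from compound 3 to compound 4 (0.22 log units; that floor lies within the scatter). This is the first step at this position to start from a measured number, but it ends on a limit, so its full size cannot be read and the step is not shown to pass the scatter. Compound 4 gives a limit, not a number: the limit of > 50000 nM in this assay, at which 2 of the 4 values shown sit.

Going by these compounds, whether the loss of the chlorine or the gain of the two methyl groups counts more stays open. So does how an amine or a carboxylic acid on this phenyl ring would read.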